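The compounds below may be only part of what the source reports. "The series", "measured", "known", "first", "only" and "open" are said of these compounds alone.

Measured so far in a functional assay on the whole organism (blood, strain Wistar-Okamoto) with Rattus norvegicus as the target, with a stated time of 5 days; on this read-out higher numbers stand for an effect only at larger amounts of compound and lower numbers for an effect already at smaller amounts:
Compound 1, `CCC/N=C(\NC#N)Nc1cccnc1`: 20 mg/kg
Compound 2, `CCCCCCC/N=C(\NC#N)Nc1cccnc1`: > 50 mg/kg, a limit of this assay rather than a number
Compound 3, `N#CN/C(=N\CC1CCCO1)Nc1cccnc1`: 50 mg/kg

Compound 3 holds the highest of the two numbers given in this assay; its nearest neighbour is compound 1, and the step of a 2.5-fold higher number from compound 1 to compound 3 (0.40 log units; beyond the scatter) lies beyond the scatter. Compound 2 reached only the limit described in the limit of > 50 mg/kg in this assay, at which 1 of the 3 values shown sits, so the step of a number no higher from compound 2 to compound 3 (the limit leaves the size open) has no readable size.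

Compound 4, `N#CN/C(=N\Cc1ccccc1)Nc1cccnc1`, has not yet been measured in this assay. It differs from compound 3 as follows: phenyl in place of oxolan-2-yl on a saturated chain carbon bound to a double-bonded nitrogen. Within the data shown here, two measured steps touch this position. The step of a 2.5-fold higher number from compound 1 to compound 3 (0.40 log units; beyond the scatter) shows that replacing ethyl by oxolan-2-yl moved the number up by a modest amount, and an at least 2.5-fold higher number from compound 1 to compound 2 (0.39 log units; beyond the scatter) shows that a longer chain pushed it to the limit. Phenyl has about the size of oxolan-2-yl, so compound 4 is expected to sit near compound 3, with a step of no change at the digits printed from compound 3 to compound 4 (within the scatter) that is expected to remain within the scatter. Compound 4 is therefore estimated at 50 mg/kg, with a range from 25 mg/kg to 100 mg/kg.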

Compound 4, minimum effective dose: 20 mg/kg
Compound 4: the middle estimate sits 2.5-fold (0.40 log units) above what was measured; the whole stated range lies above it.
By their numbers in this assay, from the lowest: compounds 1 and 4 (each within the scatter of the next); then compound 3.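

In this assay, phenyl in place of oxolan-2-yl on a saturated chain carbon bound to a double-bonded nitrogen gives a 2.5-fold lower number from compound 3 to compound 4 (0.40 log units; beyond the scatter), so this position does not treat the two ring groups alike, although they differ by only one heavy atom in the count. Phenyl in place of ethyl gives no change at the digits printed from compound 1 to compound 4 (within the scatter), which shows that a ring at this place does not have to raise the number, whereas oxolan-2-yl in place of ethyl gave a 2.5-fold higher number from compound 1 to compound 3 (0.40 log units; beyond the scatter). Phenyl in place of hexyl gives an at least 2.5-fold lower number from compound 2 to compound 4 (0.39 log units; beyond the scatter), and the size of that step stays open, as it rests on a limit rather than a number: the limit of > 50 mg/kg in this assay, at which 1 of the 4 values shown sits.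

The exchange of oxolan-2-yl for phenyl changes the ring size, the aromatic character and the ring oxygen all at once, and the compounds shown do not separate these changes from one another. As far as these compounds go, how cyclohexyl, pyridyl or a phenyl carrying a chlorine would fare at this place also remains open.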